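The source may hold more compounds than are shown below. What is called first, only, known or untested is meant among the compounds shown, and "the series" means these compounds.

The shared core is that of compound 1 `CCCn1c(-c2ccc(O)cc2)c(C)c2cc(O)ccc21`, which in a functional assay on HeLa cells (Homo sapiens) for inhibition, read by trypan blue exclusion, with a stated time of 72 h (a lower number here means a stronger inhibitor of growth, a higher number a weaker inhibitor of growth), gives 7900 nM. Compound 3 `Cc1c(-c2ccc(O)cc2)n(CCCOc2ccccc2)c2ccc(O)cc12` carries phenoxy in place of hydrogen on the chain, and in this assay compound 3 gives 4400 nM; the step of a 1.8-fold lower number from compound 1 to compound 3 (0.25 log units; within the scatter) stays within the scatter. Compound 2 `CCCn1c(-c2ccc(O)cc2)c(C)c2ccccc21` has hydrogen in place of hydroxy on the fused ring. In this assay compound 2 gives only a limit, > 20000 nM. Compound 2 thus stands at the limit, where one of the three values sits (the limit of > 20000 nM in this assay, at which 1 of the 3 values shown sits). The step of an at least 2.5-fold higher number from compound 1 to compound 2 (0.40 log units; beyond the scatter) is at least modest.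

Compound 4 `Cc1c(-c2ccc(O)cc2)[nH]c2ccccc12` differs from compound 2 by hydrogen in place of propyl on an aromatic nitrogen. Among the compounds with values here, no measured step removes this group. Within the data shown here, the only step that alters the chain on the aromatic nitrogen, a 1.8-fold lower number from compound 1 to compound 3 (0.25 log units; within the scatter), lay within the scatter, and the step of an at least 2.5-fold higher number from compound 1 to compound 2 (0.40 log units; beyond the scatter) concerns the hydroxy, not the propyl. The author therefore expects no step beyond the scatter in this assay, so that the expected step is a step that the limit leaves unreadable from compound 2 to compound 4. Compound 4 is estimated at 25000 nM, within 10000 nM to 60000 nM, and is expected most likely to return only a limit as well.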

Compound 4, concentration for 50% growth inhibition: > 20000 nM
Compound 4 was reported as a limit; the forecaster's own chance of this, stated with the estimate: 70%; the middle value is on the limit's open side.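

Compound 4, like compound 2, gives only a limit in this assay, so no step can be read between compound 2 and compound 4: the limit of > 20000 nM in this assay, at which 2 of the 4 values shown sit.

The compounds shown leave open what hydrogen in place of propyl on the aromatic nitrogen does to growth inhibition.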